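The source may hold more compounds than are shown below. What is called first, only, known or untested is meant among the compounds shown, and "the series" means these compounds.

All three measured compounds were tested in an assay on cells for inhibition of Amine oxidase [flavin-containing] B (Homo sapiens), read by fluorescence and Amplex Red, using microsomes, with a stated time of 15 min; a higher number here means a weaker inhibitor, a lower number a stronger inhibitor:

Compound 1, `Cc1ccc2oc(=O)c(C(=O)Nc3ccccc3)cc2c1`, gives 15.3 nM.
Compound 2, `Cc1cccc(NC(=O)c2cc3cc(C)ccc3oc2=O)c1`, gives 7.52 nM.
Compound 3, `Cc1cccc(NC(=O)c2coc3ccc(C)cc3c2=O)c1`, gives 17.1 nM.

Compound 3 has the highest number of the three. Its number and that of compound 1 lie within the scatter of each other, so no order can be read between them; compound 2, with a number beyond the scatter below that of compound 3, is the furthest.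

Compound 4, `Cc1ccc(NC(=O)c2coc3ccc(C)cc3c2=O)cc1`, differs from compound 3 in one place: 4-methylphenyl in place of 3-methylphenyl on an amide-type nitrogen. Going by the values given here, only one measured step speaks to any of this, a 2.0-fold lower number from compound 1 to compound 2 (0.31 log units; beyond the scatter), and it concerns adding a methyl to an unsubstituted phenyl on a different core, not shifting a methyl already present. Among the compounds with values here, no measured pair shows a 3-methylphenyl against a 4-methylphenyl on the same core, so there is no direct guide to the direction of this change. Within the data shown here, the one relevant step was modest, which suggests that the methyl position affects this assay only mildly. The expectation is therefore a step of a 1.0-fold lower number from compound 3 to compound 4 (0.00 log units; within the scatter), in effect no change beyond the scatter. Compound 4 is accordingly estimated at 17 nM, with a range from 7 nM to 40 nM.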

Compound 4, half-maximal inhibitory concentration: 152 nM
For compound 4 the middle estimate is 8.9-fold (0.95 log units) below the measured one; measured number outside the range, above it.
By their numbers in this assay, from the lowest: compound 2; then compounds 1 and 3 (each within the scatter of the next); then compound 4.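

The position of a methyl on the phenyl ring, and not only its presence, counts in this assay: putting 4-methylphenyl in place of 3-methylphenyl on the amide-type nitrogen gives an 8.9-fold higher number from compound 3 to compound 4 (0.95 log units; beyond the scatter) on the shared core. The two compounds contain the same atoms, joined differently, so this step follows the place of the methyl alone, something that the earlier step, which added a methyl on another core, could not separate from the presence of the methyl. Nothing available here explains why the number moves this way.

The compounds shown leave open whether the same shift of the methyl would give a step of similar size and direction on the core of compound 2, where only the 3-methylphenyl group appears. Going by these compounds, it also remains open how other groups, such as a methoxy group, a chlorine atom or an amine, would behave in place of the methyl on this phenyl ring, and so whether the step is particular to methyl.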